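The compounds below may be only part of what the source reports. "The series", "measured", "known", "first", "only" and "open" are said of these compounds alone.

Measured in a functional assay on MCF7 cells (Homo sapiens) for antiproliferative activity, read by MTT assay, with a stated time of 48 h; a lower number here means a stronger inhibitor, a higher number a weaker inhibitor:
- Compound 1 `CCCCCCCCn1cc(COC[C@@H]2OC[C@H](N)[C@H]2O)nn1`: > 128000 nM
- Compound 2 `CCCCCCCCCCCCCCn1cc(COC[C@@H]2OC[C@H](N)[C@H]2O)nn1`: 2450 nM

The entry for compound 1 is a limit of the assay, not a number. Among the measured compounds shown here, compound 2, at 2450 nM, therefore holds the only actual number so far. Compound 3 `CCCCCCCCCCCCCCCCn1cc(COC[C@@H]2OC[C@H](N)[C@H]2O)nn1` differs from it by ethyl in place of hydrogen on a saturated chain carbon, ten or more bonds along the chain from an aromatic nitrogen, which is ethyl in place of hydrogen on a saturated chain carbon. For the measured compounds named here, the one measured step that bears on this is the large at least 52-fold lower number from compound 1 to compound 2 (1.71 log units; beyond the scatter), which came with hexyl in place of hydrogen. Going by that step, a far smaller change in the same direction is expected in this assay for ethyl, possibly within the scatter. For compound 3 the estimated value is 1800 nM, with an expected range of 700 nM to 5000 nM. This estimate means an expected step of a 1.4-fold lower number from compound 2 to compound 3 (0.13 log units; within the scatter).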

Compound 3, half-maximal inhibitory concentration: 2260 nM
Compound 3: middle estimate off by 1.3-fold (0.10 log units), on the low side, within the range that was stated.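

In this assay ethyl on a saturated chain carbon brings a 1.1-fold lower number from compound 2 to compound 3 (0.04 log units; within the scatter) and so no change that can be told from the scatter. Octyl, eight bonds along the chain, gives an at least 56-fold lower number from compound 1 to compound 3 (1.75 log units; beyond the scatter) as a large step, so lengthening helps strongly only up to compound 2 among these compounds. For compound 1 the entry > 128000 nM is a limit of the assay, not a number. Still open, from the compounds shown here alone, is whether a longer chain would shift the value at all. Also open, going by these compounds, is what an amine or a carboxylic acid would do in place of the ethyl.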